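The source may report more compounds than this note shows. Statements on the series, on what has been measured and on what is new or still open speak of the compounds shown alone.

Compound 3 `CCCCCNC(=O)CC1CCc2cc(OC)c(OC)cc21` holds the highest of the three numbers measured in a functional assay on the whole organism (strain Wistar) for inhibition, with Rattus norvegicus as the target, read by paw edema, with stated times of 60 min and 24 h, at a dose of 100 mg/kg by the oral route (on this read-out lower numbers stand for less inhibition and higher numbers for more inhibition at the one dose given (going by the name of the read-out)), where compound 3 gives 46.7%. Compound 1 `COc1cc2c(cc1OC)C(CC(N)=O)CC2` gives 26.7%, and compound 2 `COc1cc2c(cc1OC)C(CC(=O)N(C)C)CC2` gives 23.3%. Changing the group on the amide-type nitrogen gave a number 20 percentage points higher from compound 1 to compound 3 (beyond the scatter) and a number 23.4 percentage points higher from compound 2 to compound 3 (beyond the scatter), while a number 3.4 percentage points lower from compound 1 to compound 2 (within the scatter). Compound 4 `COc1cc2c(cc1OC)C(CC(=O)NC1CCCC1)CC2` differs from compound 3 in one place: cyclopentyl in place of pentyl on an amide-type nitrogen. Going by the values given here, no measured step alters the pentyl group itself, so the two steps that lead to compound 3 are the only guide, and pentyl and cyclopentyl are counted alike in heavy atoms. The step is therefore expected to be a number 1.7 percentage points lower from compound 3 to compound 4 (within the scatter), within the scatter. Compound 4 is estimated at 45%, with a range from 30% to 60%.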

Compound 4, a percentage reported as inhibition, in the whole organism at one dose (the size of the read-out at that dose, not a potency): 46.7%
Estimate against measurement, compound 4: 1.7 percentage points below, and the stated range covers the measured number.
By their numbers in this assay, from the lowest: compounds 2 and 1 (each within the scatter of the next); then compounds 3 and 4 (each within the scatter of the next).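

In this assay, closing the open pentyl chain into a cyclopentyl ring of the same heavy-atom count gives no change at the digits printed from compound 3 to compound 4 (within the scatter), so at this amide-type nitrogen the ring and the chain read alike. The rise over the plain amide and the dimethylamino amide holds for the ring as well, with a number 23.4 percentage points higher from compound 2 to compound 4 (beyond the scatter) and a number 20 percentage points higher from compound 1 to compound 4 (beyond the scatter). Nothing available explains why the two groups read alike. Still open, on these data alone, is how a longer chain such as octyl, or a benzyl group, on this nitrogen would read at this single dose.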